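A few compounds are considered here, and "the series" means these few. Any claim that something is new, unique, unknown or untested is made for them only; others in the source may bear on it.

Compound 1 `CC(C)C(c1ncc[nH]1)c1ccc(-c2ccc3cccc(F)c3c2)[nH]c1=O`: < 0.0667 h
Compound 2 `CC(C)NC(=O)CC(c1ccc(-c2ccc3cccc(F)c3c2)[nH]c1=O)C(C)C`: < 0.0667 h
Compound 3 `CC(C)C(c1ccc(-c2ccc3cccc(F)c3c2)[nH]c1=O)N1CCN/C1=N\C#N`: 0.207 h

In an ADME assay on microsomes from liver (Mus musculus) for metabolic stability (on this read-out lower numbers stand for a shorter-lived compound and higher numbers for a longer-lived compound), compound 1 gives < 0.0667 h, which is a limit of the assay rather than a number. Compound 2 likewise gives only the limit < 0.0667 h in this assay. Compound 3 reaches 0.207 h. Of compound 1 the data therefore hold only a limit, and it sits together with compound 2 at the limit of < 0.0667 h in this assay, at which 2 of the 3 values shown sit.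

Compound 4 `CC(C)C(Cc1nnn[nH]1)c1ccc(-c2ccc3cccc(F)c3c2)[nH]c1=O` differs from compound 1 in one place: (1H-tetrazol-5-yl)methyl in place of 1H-imidazol-2-yl on a saturated chain carbon bound to an aromatic carbon and a saturated chain carbon. Two measured steps start from the same carbon. The step of an at least 3.1-fold higher number from compound 1 to compound 3 (0.49 log units; beyond the scatter) shows that exchanging the 1H-imidazol-2-yl group for a different group can lift the half-life beyond the scatter, whereas the step that the two limits leave unreadable from compound 1 to compound 2 cannot be read because both ends are limits. The change to compound 4 keeps a five-membered aromatic ring on that carbon, so the cautious expectation is little movement from the limit, with a modest rise possible. Compound 4 is thus expected to give 0.08 h in this assay, between 0.04 h and 0.2 h, a step of an at least 1.1-fold higher number from compound 1 to compound 4 (0.07 log units; that floor lies within the scatter).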

Compound 4, half-life: 0.853 h
Compound 4: the middle estimate sits 11-fold (1.03 log units) below what was measured; measured number above the stated range.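

On the saturated chain carbon bound to an aromatic carbon and a saturated chain carbon, the group placed there can take the half-life in this assay far clear of the limit, with an at least 12-fold higher number from compound 1 to compound 4 (1.10 log units; beyond the scatter) and an at least 12-fold higher number from compound 2 to compound 4 (1.10 log units; beyond the scatter). Among the compounds shown here, the (1H-tetrazol-5-yl)methyl group also goes past the non-aromatic ring of the only earlier compound with a readable value, with a 4.1-fold higher number from compound 3 to compound 4 (0.61 log units; beyond the scatter). Both larger steps start from a limit, so they give only a minimum size, and compound 1 and compound 2 each remain a limit rather than a number: the limit of < 0.0667 h in this assay, at which 2 of the 4 values shown sit.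

Going by these compounds, compound 4 differs from compound 1 in both the ring and the added methyl link, so the share of each in the rise remains open. On these data alone, it is also open whether a 1H-tetrazol-5-yl set directly on that carbon, or a carboxylic acid on the same chain, would hold this half-life.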